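The compounds below may be only part of what the source reports. "The series", "measured", "known", "first", "only" and "open" are said of these compounds alone.

In an assay on HEK293 cells for inhibition of prostaglandin E2 receptor EP4 subtype (Rattus norvegicus) (a higher number here means a weaker inhibitor, a lower number a stronger inhibitor), compound 1 `CCCCc1ccc(CN(Cc2ccccc2OCC(=O)O)S(C)(=O)=O)cc1` gives only a limit, > 3200 nM. Compound 2 `CC(C)(C)c1ccc(CN(Cc2cccc(CCC(=O)O)c2)S(=O)(=O)c2ccccc2)cc1` likewise gives only a limit in this assay, > 3200 nM. Among the compounds with values here, the two values share (the limit of > 3200 nM in this assay, at which 2 of the 2 values shown sit), so no number stands for either compound and no step between measured compounds can be read. Compound 3 `CC(C)(C)c1ccc(CN(Cc2cccc(CCC(=O)O)c2)S(=O)(=O)c2ccccn2)cc1` differs from compound 2 by pyridin-2-yl in place of phenyl on a sulfonyl sulfur. Within the data shown here, with no measured step to lean on, the step expected here is an at least 1.0-fold lower number from compound 2 to compound 3 (0.02 log units; that floor lies within the scatter), none beyond the scatter in either direction. Compound 3 is therefore estimated at 3000 nM, within a range from 800 nM to 10000 nM.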

Compound 3, half-maximal inhibitory concentration: > 3200 nM
Compound 3: a limit, no number; the forecaster's own chance of this, stated with the estimate: 65%; middle value at least 1.0-fold (0.02 log units) away from the limit.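

Compound 3 also gives only a limit, so no new step can be read from compound 2 to compound 3: the limit of > 3200 nM in this assay, at which 3 of the 3 values shown sit.

What the compounds shown leave open is whether pyridin-2-yl in place of phenyl on a sulfonyl sulfur changes the number at all.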